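The source may report more compounds than this note shows. Statements on the series, on what has been measured and on what is new or still open speak of the compounds shown alone.

Measured so far:
Compound 1 `C=CCc1cc(C(=O)N[C@H](C)CCCc2cccnc2)ccc1-c1ccc(OC)c(OC)c1` gives 80 nM in an assay (Canis lupus familiaris) for binding affinity to platelet-activating factor receptor (Homo sapiens), read by radioligand binding; on this read-out lower numbers stand for stronger inhibition and higher numbers for weaker inhibition.
Compound 2 `COc1ccc(-c2ccc(C(=O)NCCCCc3cccnc3)cc2OC)cc1OC` gives 300 nM in this assay.
Compound 3 `O=C(NCCCCc1cccnc1)c1ccc(-c2cccc(F)c2)c(F)c1` gives 2100 nM in this assay.

Compound 2 stands second of the three numbers, with compound 1 at a lower number and compound 3 at a higher one, both gaps beyond the scatter. The next compound, compound 4 `COc1ccc(-c2ccc(C(=O)NCCCCc3cccnc3)cc2[N+](=O)[O-])cc1OC`, differs from compound 2 in one place: nitro in place of methoxy on an aromatic carbon. Among the compounds with values here, no measured pair shows this exchange, so the direction is uncertain. The other two compounds carry different groups at that position and differ elsewhere too, so they give no clean guide. The step from compound 2 to compound 4 in this assay is expected to be small, at most a modest move toward weaker inhibition, and may lie within the scatter. Compound 4 is estimated at 500 nM, in the range 150 nM to 1800 nM, a step of a 1.7-fold higher number from compound 2 to compound 4 (0.22 log units; within the scatter).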

Compound 4, half-maximal inhibitory concentration: 200 nM
Beside the measured number, compound 4's estimate is 2.5-fold (0.40 log units) above it; measured number inside the range.
By their numbers in this assay, from the lowest: compound 1; then compounds 4 and 2 (each within the scatter of the next); then compound 3.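

In this assay, nitro in place of methoxy on an aromatic carbon, ortho to a 3,4-dimethoxyphenyl group, gives a 1.5-fold lower number from compound 2 to compound 4 (0.18 log units; within the scatter). This position therefore takes either group without a shift beyond the scatter, although the exchange raises the counts of heavy atoms and hydrogen-bond acceptors. No supporting data explain this reading. As far as these compounds go, whether an amine, a carboxylic acid or a plain hydrogen at this position would hold the number in the same range stays open. So does whether the exchange would read the same on the core of compound 1.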